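Aryl variation on the triazole nitrogen: cytotoxicity notes

The compounds below may be only part of what the source reports. "The series", "measured", "known", "first", "only" and "open" are said of these compounds alone.

In a functional assay on NCI-H322 cells (Homo sapiens) for cytotoxicity, read by MTT assay, with a stated time of 24 h (on this read-out lower numbers stand for stronger inhibition and higher numbers for weaker inhibition), compound 2 `COc1ccc(/C=C\C(=O)O)c(OCc2cn(-c3ccc(CO)cc3)nn2)c1CC=C(C)C` gives 27100 nM. That is the highest of the two numbers seen so far, but its nearest neighbour, compound 1 `COc1cccc(-n2cc(COc3c(/C=C\C(=O)O)ccc(OC)c3CC=C(C)C)nn2)c1`, sits within the scatter: compound 1 gives 25200 nM in this assay. Among the measured compounds shown here, the one measured step, a 1.1-fold higher number from compound 1 to compound 2 (0.03 log units; within the scatter), shows that swapping one aryl group for another on the aromatic nitrogen left the read-out essentially unchanged.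

Compound 3 `COc1ccc(/C=C\C(=O)O)c(OCc2cn(-c3cccc([N+](=O)[O-])c3)nn2)c1CC=C(C)C` is unmeasured. It differs from compound 2 in one place: 3-nitrophenyl in place of 4-(hydroxymethyl)phenyl on an aromatic nitrogen. For the measured compounds named here, no measured step involves a nitro-bearing aryl group, so the only guide is that the aryl change from compound 1 to compound 2 stayed within the scatter. On that basis no step beyond the scatter is expected from compound 2 to compound 3; the expected step is a 1.0-fold lower number from compound 2 to compound 3 (0.00 log units; within the scatter). Compound 3 is therefore estimated at 27000 nM in this assay, with a range from 12000 nM to 60000 nM.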

Compound 3, half-maximal inhibitory concentration: 43200 nM
For compound 3 the middle estimate is 1.6-fold (0.20 log units) below the measured one; the measured number falls inside the stated range.
By their numbers in this assay, from the lowest: compounds 1, 2 and 3 (each within the scatter of the next).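

The aryl group on the aromatic nitrogen also accepts a nitro-bearing ring in this assay: 3-nitrophenyl in place of 4-(hydroxymethyl)phenyl gives a 1.6-fold higher number from compound 2 to compound 3 (0.20 log units; within the scatter), so a hydrogen-bond donor on this aryl group is not needed to keep the number within the scatter. The comparison with the 3-methoxyphenyl compound, nitro in place of methoxy on an aromatic carbon, gives a 1.7-fold higher number from compound 1 to compound 3 (0.23 log units; within the scatter) and likewise shows no separation across the three aryl groups. Nothing measured here accounts for the size of these steps.

On these data alone, whether an aryl group carrying an amine or a carboxylic acid would move the number beyond the scatter stays open. Nitro appears only as 3-nitrophenyl and hydroxymethyl only as 4-(hydroxymethyl)phenyl, so the placement on the ring cannot be separated from the group itself.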